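The source may report more compounds than this note shows. Statements on the series, on what has been measured and on what is new or still open speak of the compounds shown alone.

Going by the values given here, compound 1 `C=CC(=O)Nc1cccc(Nc2nc(Nc3ccc(OCCn4ccnc4)cc3)ncc2F)c1` is one of two compounds measured in a functional assay on A-431 cells (Homo sapiens) for antiproliferative activity, read by MTT assay, with a stated time of 48 h; on this read-out lower numbers stand for stronger inhibition and higher numbers for weaker inhibition. In this assay compound 1 gives 2480 nM, the lowest number of the two, while compound 2 `C=CC(=O)Nc1cccc(Nc2nc(Nc3ccc(Cn4ccnc4)cc3OC)ncc2Cl)c1`, which differs from it in several places, gives 6780 nM; the two values lie beyond the scatter of each other. Compound 3 `C=CC(=O)Nc1cccc(Nc2nc(Nc3ccc(Cn4ccnc4)cc3)ncc2F)c1` has not yet been measured in this assay. It is reached from compound 1 by a single change: (1H-imidazol-1-yl)methyl in place of 2-(1H-imidazol-1-yl)ethoxy on an aromatic carbon. Among the compounds with values here, no pair of measured compounds shows this change alone, so the size of the step is not known from the measured data; a modest step toward weaker inhibition is expected, though one that may still fall within the scatter. Compound 3 is therefore expected to give about 3500 nM in this assay, between 1200 nM and 10000 nM, a step of a 1.4-fold higher number from compound 1 to compound 3 (0.15 log units; within the scatter) that is estimated rather than measured.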

Compound 3, half-maximal inhibitory concentration: 152 nM
Compound 3: the middle estimate sits 23-fold (1.36 log units) above what was measured, and the stated range ends above it.
By their numbers in this assay, from the lowest: compound 3; then compound 1; then compound 2.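

In this assay, the aromatic carbon para to a large group proves sensitive to how the imidazole ring is attached: (1H-imidazol-1-yl)methyl in place of 2-(1H-imidazol-1-yl)ethoxy gives a 16-fold lower number from compound 1 to compound 3 (1.21 log units; beyond the scatter), a large step. The five-membered aromatic ring is present on both sides of this change, so the step goes with the connecting chain, which is shorter in the entering group and holds no oxygen. No measurement shown here accounts for the size of this step.

The compounds shown do not separate the effect of chain length from that of losing the oxygen, which a 2-(1H-imidazol-1-yl)ethyl group would help to resolve. Going by these compounds, it also remains open whether the methylene connection would hold its value with a morpholine ring in place of the imidazole.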